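A few compounds are considered here, and "the series" means these few. Any claim that something is new, unique, unknown or untested is made for them only; others in the source may bear on it.

Within the data shown here, in a functional assay on MCF7 cells (Homo sapiens) for antiproliferative activity, read by MTT assay, with a stated time of 48 h (a lower number here means a stronger inhibitor, a higher number a weaker inhibitor), compound 2 (`CC(C)=CCC[C@]1(C)/C=C/[C@@H](OC(=O)C=C(C)C)[C@](C)(O)/C=C/C(=O)/C(Cn2cc(CO)nn2)=C\C1`) gives 2930 nM, the lower of the two numbers measured so far, while compound 1 (`CC(C)=CCC[C@]1(C)/C=C/[C@@H](OC(=O)C=C(C)C)[C@](C)(O)/C=C/C(=O)/C(C[Si](C)(C)C(C)(C)C)=C\C1`) gives 6040 nM. Compound 3 (`CSC(=S)OC/C1=C/C[C@](C)(CCC=C(C)C)/C=C/[C@@H](OC(=O)C=C(C)C)[C@](C)(O)/C=C/C1=O`) shares its core with compound 2 and differs in one group: a group of 5 heavy atoms (2 carbon, 1 oxygen, 2 sulfur; no ring) in place of a group of 7 heavy atoms (3 carbon, 3 nitrogen, 1 oxygen; one five-membered aromatic ring with 3 hetero atoms), on a saturated chain carbon bound to a double-bonded ring carbon. The 4-(hydroxymethyl)-1H-1,2,3-triazol-1-yl group leaves, and the group that enters has no ring. Among the measured compounds shown here, only one measured step bears on this change, a 2.1-fold lower number from compound 1 to compound 2 (0.31 log units; beyond the scatter), which is modest but beyond the scatter and involved an exchange at the same place. With that single step as the guide, a shift of similar or smaller size is expected in this assay, more likely towards a higher number, and it may not exceed the scatter. The expected change is a 1.2-fold higher number from compound 2 to compound 3 (0.08 log units; within the scatter). For compound 3, the estimated value is 3500 nM, with an expected range from 1300 nM to 9500 nM.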

Compound 3, half-maximal inhibitory concentration: 900 nM
Beside the measured number, compound 3's estimate is 3.9-fold (0.59 log units) above it, outside the stated range (below it).
By their numbers in this assay, from the lowest: compound 3; then compound 2; then compound 1.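

In this assay, replacing the 4-(hydroxymethyl)-1H-1,2,3-triazol-1-yl group on the saturated chain carbon with the group containing two sulfur atoms gives a 3.3-fold lower number from compound 2 to compound 3 (0.51 log units; beyond the scatter), showing that this place can lower the number further than the triazole did. The exchange of the silicon-containing group for the same sulfur-containing group gives a 6.7-fold lower number from compound 1 to compound 3 (0.83 log units; beyond the scatter), so the two groups with no ring now stand at opposite ends of the series, with the ring-bearing compound 2 between them, and the presence of a ring alone does not set the order among these three compounds. Nothing given here accounts for these steps. As far as these compounds go, it remains open whether an amine or a simple acetate ester at this place would fall nearer to compound 3 or to compound 2. From the compounds shown here alone, it is equally open whether the sulfur atoms are needed for the lower number, and whether a triazole carrying a longer chain instead of hydroxymethyl would shift it.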